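Amide series: cyano to fluoro on the pyridine-bearing side

The source may report more compounds than this note shows. Statements on the series, on what has been measured and on what is new or still open speak of the compounds shown alone.

Two compounds of the series have a measurement. Compound 1 `Cc1ccnc(NC(=O)c2ccccc2C)c1` gives 2.8 in a physicochemical assay for lipophilicity, read by HPLC, at pH 7.4; on this read-out lower numbers stand for lower lipophilicity and higher numbers for higher lipophilicity. Compound 2 `Cc1ccccc1C(=O)Nc1ccc(C#N)cn1` gives 3.9 in this assay. On these two numbers compound 2 stands highest; its nearest neighbour is compound 1, a number lower by a gap that lies beyond the scatter. Within the data shown here, no single-change step between measured compounds exists in this set, so nothing measured tells directly how a change at this position moves the read-out.

Compound 3 `Cc1ccccc1C(=O)Nc1ccc(F)cn1` is not yet measured. It differs from compound 2 in one place: fluoro in place of cyano on an aromatic carbon. The change sits on the aromatic carbon two atoms from the ring nitrogen, para to a large group.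

Among the measured compounds shown here, with no measured step to lean on, the expectation rests on the value of compound 2 alone. The step from compound 2 to compound 3 is expected to be a number 0.40 log units higher from compound 2 to compound 3 (beyond the scatter), a modest rise, though a result within the scatter would not be surprising. Compound 3 is therefore estimated at 4.3, with a range from 3.8 to 4.8.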

Compound 3, distribution coefficient: 2.7
Estimate against measurement, compound 3: 1.60 log units above, and the stated range ends above it.
By their numbers in this assay, from the lowest: compounds 3 and 1 (each within the scatter of the next); then compound 2.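

Among these compounds, the position is not silent: in this assay, fluoro in place of cyano on the aromatic carbon two atoms from the ring nitrogen gives a number 1.20 log units lower from compound 2 to compound 3 (beyond the scatter) as the first single-change step. This large step lies beyond the scatter, so the read-out of this series can depend strongly on the group held at this one place. The high number of compound 2 therefore does not carry over to compound 3, even though the two share the rest of their structure. No measurement among the data shown bears on why the step has this size and direction.

The compounds shown give a single step at this position, so it remains open whether other groups, such as an amine, a methoxy group or a carboxylic acid on the same aromatic carbon, would fall close to fluoro, close to cyano or elsewhere. On these data alone, it also remains open whether the same exchange of cyano for fluoro would give a step of similar size at another place on the ring or on a different core.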